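Methoxy in place of chloro on L6 cells

The source may hold more compounds than are shown below. What is called first, only, known or untested is meant among the compounds shown, and "the series" means these compounds.

In an ADME assay on L6 cells (Rattus norvegicus) for cytotoxicity, read by resazurin assay, with a stated time of 72 h (on this read-out lower numbers stand for stronger inhibition and higher numbers for weaker inhibition), compound 1 (`N=C(N)c1ccc(OCc2ccc([N+](=O)[O-])cc2)c(I)c1`) gives 10700000 nM and compound 2 (`N=C(N)c1ccc(COc2ccc(Cl)cc2)cc1`) gives 20700000 nM with the two values lying within the usual scatter of each other. Compound 3 (`COc1ccc(OCc2ccc(C(=N)N)cc2)cc1`) differs from compound 2 by methoxy in place of chloro on an aromatic carbon, para to a large group (methoxy in place of chloro on an aromatic carbon). Among the compounds with values here, no measured pair shows this change, so no step beyond the scatter is expected in either direction. The expected change is small, an estimated 1.2-fold higher number from compound 2 to compound 3 (0.08 log units; within the scatter) in this assay on this reasoning. Compound 3 is estimated at 25000000 nM with an expected range from 10000000 nM to 60000000 nM on this read-out.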

Compound 3, half-maximal inhibitory concentration: 143000000 nM
Beside the measured number, compound 3's estimate is 5.7-fold (0.76 log units) below it; the whole stated range lies below it.
By their numbers in this assay, from the lowest: compounds 1 and 2 (each within the scatter of the next); then compound 3.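

In this assay methoxy in place of chloro on an aromatic carbon, para to a large group, gives a 6.9-fold higher number from compound 2 to compound 3 (0.84 log units; beyond the scatter) and so moves the read-out towards weaker inhibition. Within the data shown here, this is the first sign that this position responds to a change of substituent, since compound 1 and compound 2 differ in more than one place. Nothing given here accounts for the size of this step. A single pair cannot show whether this step holds for other substituents on this carbon. As far as these compounds go, how a fluoro, a hydroxyl or an amine at this position would compare with chloro and methoxy remains open.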